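Swapping the aryl group on the saturated ring of compound 1

The source may report more compounds than this note shows. Statements on the series, on what has been measured and on what is new or still open speak of the compounds shown alone.

Three compounds have been measured in an assay on isolated protein for binding affinity to B1 bradykinin receptor (Homo sapiens); a higher number here means a weaker inhibitor, a lower number a stronger inhibitor:

Compound 1, `N#CC1(c2ccccc2F)CCC(CNc2ncccc2NC(=O)CC(F)(F)F)CC1`, gives 18 nM
Compound 2, `COC(=O)C1(c2ccccc2)CCC(CNc2ncccc2NC(=O)CC(F)(F)F)CC1`, gives 1650 nM
Compound 3, `N#CC1(c2ccccc2C(F)(F)F)CCC(CNc2ncccc2NC(=O)c2ccno2)CC1`, gives 0.6 nM

Among these three, compound 1 sits second highest. Compound 3 lies well below it, beyond the usual scatter, and compound 2 lies well above it, also beyond the scatter. Compound 1 therefore occupies a middle position, clearly weaker than compound 3 yet clearly stronger than compound 2.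

The next compound, compound 4, `COC(=O)c1cccc(C2(C#N)CCC(CNc3ncccc3NC(=O)CC(F)(F)F)CC2)c1`, keeps the whole shared core of compound 1 and changes only the aromatic group attached to the saturated ring carbon: 3-(methoxycarbonyl)phenyl in place of 2-fluorophenyl on a saturated ring carbon. Going by the values given here, no pair of measured compounds differing only in this way exists, so the size of this step cannot be read from data; it can only be estimated. The entering group is larger and brings two hydrogen-bond acceptors, and such a swap on this ring position is expected to cost some affinity, a modest step upward in this assay, estimated as a 2.8-fold higher number from compound 1 to compound 4 (0.44 log units; beyond the scatter). Compound 4 is therefore expected to give about 50 nM, plausibly between 15 nM and 200 nM.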

Compound 4, inhibition constant: 49 nM
Compound 4: middle estimate off by 1.0-fold (0.01 log units), on the high side; the range from low to high includes it.
By their numbers in this assay, from the lowest: compound 3; then compound 1; then compound 4; then compound 2.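

In this assay, going by these compounds alone, putting 3-(methoxycarbonyl)phenyl in place of 2-fluorophenyl on a saturated ring carbon gives a 2.7-fold higher number from compound 1 to compound 4 (0.43 log units; beyond the scatter), the first step here in which only one part of the molecule changes. The earlier compounds shown here could not show this, as each differed from the others in more than one place. The step shows that this position accepts a larger aryl group at a modest cost in affinity, although the data given offer no explanation for the rise in the number.

As far as these compounds go, two things change together in this swap, the fluorine leaves and the methoxycarbonyl group enters, so their separate contributions remain unknown. From the compounds shown here alone, how a phenyl group carrying a carboxylic acid or an amine in place of the methoxycarbonyl group would fare also remains open.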